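The source may hold more compounds than are shown below. What is called first, only, known or untested is meant among the compounds shown, and "the series" means these compounds.

Of the compounds shown here, two have been measured so far in a functional assay on PSN1 cells (Homo sapiens) for inhibition (on this read-out lower numbers stand for stronger inhibition of growth and higher numbers for weaker inhibition of growth), and they are these.

- compound 1 `C/C=C/C=C/C(=O)C[C@H](CCO)OC` with 50000 nM
- compound 2 `C/C=C/C=C/C(=O)CC(CCO)OCC[C@H](O)CC(=O)CC/C=C/C` with 28000 nM

Compound 2 stands level with compound 1 on these numbers, the two lying within the scatter of each other. Compound 3 `C/C=C/C=C/C(=O)CC(CCO)OCC[C@H](O)CC(=O)/C=C/C=C/C` departs from compound 2 by penta-1,3-dien-1-yl in place of pent-3-en-1-yl on a carbonyl carbon on a carbonyl carbon. Among the measured compounds shown here, no measured pair shows this change, so any expectation is loose. A small move toward stronger inhibition of growth in this assay is expected, not clearly beyond the scatter, an estimated 1.9-fold lower number from compound 2 to compound 3 (0.27 log units; within the scatter) in size. For compound 3 the estimate is 15000 nM with an expected range from 4000 nM to 40000 nM on this read-out.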

Compound 3, concentration for 50% growth inhibition: 29000 nM
Beside the measured number, compound 3's estimate is 1.9-fold (0.29 log units) below it; low and high end bracket the measured number.
By their numbers in this assay, from the lowest: compounds 2, 3 and 1 (each within the scatter of the next).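

Among the compounds shown here, with penta-1,3-dien-1-yl in place of pent-3-en-1-yl on a carbonyl carbon, this assay gives a 1.0-fold higher number from compound 2 to compound 3 (0.02 log units; within the scatter) and this is the first measured step at this position. For this one pair, the second double bond outside aromatic rings in the five-carbon chain leaves the two numbers level. Nothing measured here offers an account of this result. From the compounds shown here alone, it stays open whether an amine, a carboxylic acid or a longer chain on this carbonyl carbon would move the number beyond the scatter. One pair also cannot show whether the same change would read alike on another core.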